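Furan-3-yl for Thiophen-3-yl: What to Expect of Compound 4

The source may hold more compounds than are shown below. What is called first, only, known or untested is meant among the compounds shown, and "the series" means these compounds.

Of the compounds shown here, three have been tested in a functional assay on HL-60 cells (Homo sapiens) for antiproliferative activity, read by XTT assay, with a stated time of 72 h; on this read-out higher numbers stand for weaker inhibition and lower numbers for stronger inhibition. Compound 1 `COc1ncnc2c1c(-c1ccsc1)cn2[C@@H]1O[C@H](CO)[C@@H](O)[C@H]1O` gives 130 nM in this assay. Compound 2 `COc1ncnc2c1c(-c1ccoc1)cn2[C@@H]1O[C@H](CO)[C@@H](O)[C@H]1O` differs from compound 1 only by furan-3-yl in place of thiophen-3-yl on an aromatic carbon, and in this assay compound 2 gives 150 nM; the step of a 1.2-fold higher number from compound 1 to compound 2 (0.06 log units; within the scatter) lies within the scatter, so the two values count as alike. Compound 3 `CNc1ncnc2c1c(-c1ccsc1)cn2[C@@H]1O[C@H](CO)[C@@H](O)[C@H]1O` carries a different core, and the difference between the two cores is methylamino in place of methoxy on an aromatic carbon. In this assay compound 3 reaches only the limit > 20000 nM, which is a boundary of the measurement rather than a number. The step of an at least 150-fold higher number from compound 1 to compound 3 (2.18 log units; beyond the scatter) is accordingly large. Compound 4 `CNc1ncnc2c1c(-c1ccoc1)cn2[C@@H]1O[C@H](CO)[C@@H](O)[C@H]1O` has not yet been measured; it stands to compound 3 as compound 2 stands to compound 1, through (furan-3-yl in place of thiophen-3-yl on an aromatic carbon), at the very same place. Because a 1.2-fold higher number from compound 1 to compound 2 (0.06 log units; within the scatter) was within the scatter, a step of the same small size, a step that the limit leaves unreadable from compound 3 to compound 4, is expected here. Compound 4 is therefore expected to remain at the limit, around 30000 nM.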

Compound 4, half-maximal inhibitory concentration: > 15000 nM
Compound 4 was reported as a limit; the forecaster's own chance of this, stated with the estimate: 85%; the middle value is on the limit's open side.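

With furan-3-yl in place of thiophen-3-yl, putting methylamino in place of methoxy again gives a large loss of activity in this assay, with an at least 100-fold higher number from compound 2 to compound 4 (2.00 log units; beyond the scatter). Set side by side, the change keeps its direction and stays large when carried from one core to the other, but its exact size on each core remains unknown: the same change on two cores in this assay, an at least 150-fold higher number (2.18 log units; beyond the scatter) from compound 1 to compound 3 and an at least 100-fold higher number (2.00 log units; beyond the scatter) from compound 2 to compound 4; the limit leaves it open whether they differ. Compound 3 and compound 4 are both reported only as limits of the measurement, not as numbers; the step between them cannot be read, and this pair does not show whether furan-3-yl and thiophen-3-yl give alike results on the methylamino core.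

From the compounds shown here alone, it remains open whether a dimethylamino or an ethoxy group in place of methoxy would give a value closer to that of compound 1 or to the limit of compound 3. Going by these compounds, it is also open how a phenyl group in place of thiophen-3-yl would fare on either core.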